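The source may hold more compounds than are shown below. What is called first, only, known or untested is meant among the compounds shown, and "the series" means these compounds.

In an ADME assay on Akata cells (Homo sapiens) for cytotoxicity, with a stated time of 7 days (a higher number here means that more compound is tolerated, a lower number that less compound is tolerated), compound 1 `Nc1nc(NC2CCCCC2)c2ncn(/C=C3/CC3(CO)CO)c2n1` gives > 24000 nM, a limit of the assay. Compound 2 `Nc1nc(NCc2ccccc2)c2ncn(/C=C3/CC3(CO)CO)c2n1` gives > 24000 nM, also a limit. Compound 3 `CCCSc1nc(N)nc2c1ncn2/C=C1/CC1(CO)CO` gives > 20000 nM, again a limit.

Compound 3 therefore stands at a limit, as do the two others; with one value at the limit of > 20000 nM in this assay, at which 1 of the 3 values shown sits, and two at the limit of > 24000 nM in this assay, at which 2 of the 3 values shown sit, the steps a step that the two limits leave unreadable from compound 1 to compound 3 and a step that the two limits leave unreadable from compound 2 to compound 3 cannot be sized, and neither can a step that the two limits leave unreadable from compound 1 to compound 2. Compound 4 `CCOc1nc(N)nc2c1ncn2/C=C1/CC1(CO)CO` differs from compound 3 as follows: ethoxy in place of propylsulfanyl on an aromatic carbon. Among the measured compounds shown here, no measured step covers this change, and the measured steps give no readable size at all. Compound 4 is expected to remain tolerated, with an estimated 25000 nM (range 12000 nM to 50000 nM). The expected step that the limit leaves unreadable from compound 3 to compound 4 is thus none beyond the scatter, most likely again reported only as a limit.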

Compound 4, half-maximal cytotoxic concentration: > 20000 nM
Compound 4: only a limit was reported (the forecaster's own chance of this, stated with the estimate: 85%); the middle value does not contradict the limit.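

In this assay compound 4 gives > 20000 nM, a limit, so steps between compound 4 and compound 1, compound 2 or compound 3 cannot be read. The compounds shown leave open whether these groups on the aromatic carbon differ in tolerated concentration at all.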